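A Phenoxymethyl Amide Replaces a Methyl Carbamate

A few compounds are considered here, and "the series" means these few. Any claim that something is new, unique, unknown or untested is made for them only; others in the source may bear on it.

Compound 1 `CCCCOC(=O)CNC(=O)[C@H](CSc1ccc([N+](=O)[O-])cc1[N+](=O)[O-])NC(=O)CC[C@H](NC(C)=O)C(=O)OCCCC` and compound 2 `CCCCOC(=O)CNC(=O)[C@H](CSc1ccc([N+](=O)[O-])cc1[N+](=O)[O-])NC(=O)CC[C@H](NC(=O)OC)C(=O)OCCCC` share one core and differ only in the group on the carbonyl carbon of the protecting amide. In a toxicity assay on KB cells (Homo sapiens) for cytotoxicity, read by fluorescence, with a stated time of 3 days (on this read-out lower numbers stand for an effect already at smaller amounts and higher numbers for an effect only at larger amounts of compound), compound 1 gives > 300 uM, which is a limit of the assay and not a number. Compound 2 likewise gives only the limit > 300 uM in this assay. The step that the two limits leave unreadable from compound 1 to compound 2 therefore cannot be read in size or direction. Where compound 2 stands is thus fixed only by the limit of > 300 uM in this assay, at which 2 of the 2 values shown sit.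

Compound 3 `CCCCOC(=O)CNC(=O)[C@H](CSc1ccc([N+](=O)[O-])cc1[N+](=O)[O-])NC(=O)CC[C@H](NC(=O)COc1ccccc1)C(=O)OCCCC` differs from compound 2 by phenoxymethyl in place of methoxy on a carbonyl carbon. Going by the values given here, no measured step bears directly on this change, since the one step available, from compound 1 to compound 2, is unreadable. The expectation for compound 3 rests only on the fact that both measured compounds sit at the limit of > 300 uM in this assay, at which 2 of the 2 values shown sit, so no movement beyond the scatter is anticipated. Compound 3 is accordingly expected to give about 300 uM in this assay, within a range of 100 uM to 1000 uM. The step of a number no higher from compound 2 to compound 3 (the limit leaves the size open) that this estimate implies is expected to be essentially flat, and most probably compound 3 will again return only a limit.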

Compound 3, concentration for half-maximal effect: > 300 uM
Compound 3: only a limit was reported; the forecaster's own chance of this, stated with the estimate: 80%; the middle value sits exactly at the limit.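

In this assay compound 3 gives > 300 uM, which is a limit of the assay and not a number, so its steps from compound 1 and compound 2 cannot be read in size or direction. The series stands as follows: the limit of > 300 uM in this assay, at which 3 of the 3 values shown sit.

The compounds shown leave open whether methyl, methoxy and phenoxymethyl on this carbonyl carbon differ at all in this assay.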